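The source may report more compounds than this note shows. Statements on the series, on what has been measured and on what is new or still open speak of the compounds shown alone.

Compound 1, `COC(=O)C(C)(C)NC(=O)c1cc(F)cc2cc(-c3ccc(Cl)cc3)oc12`, in an assay on isolated protein for inhibition of endoplasmic reticulum aminopeptidase 1 (Homo sapiens), with stated times of 15 min and 20 min (on this read-out lower numbers stand for stronger inhibition and higher numbers for weaker inhibition), gives > 10000 nM, which is a limit of this assay, not a number.
Compound 2, `CC(C)(NC(=O)c1cc(F)cc2cc(-c3ccc(Cl)cc3)oc12)c1nnn[nH]1`, in this assay gives 275 nM.

Among the compounds with values here, compound 2 carries the only measured number in this assay; the other value shown is a limit (the limit of > 10000 nM in this assay, at which 1 of the 2 values shown sits). The step of an at least 36-fold lower number from compound 1 to compound 2 (1.56 log units; beyond the scatter) shows that exchanging the methoxycarbonyl group for a tetrazole moved the compound from a limit to a measurable number.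

Compound 3, `C[C@H](NC(=O)c1cc(F)cc2cc(-c3ccc(Cl)cc3)oc12)C(=O)O`, differs from compound 2 by the change (1-carboxyethyl in place of 1-(1H-tetrazol-5-yl)-1-methylethyl on an amide-type nitrogen). Within the data shown here, the single measured step bears on it only indirectly: it shows that a methyl ester at this position gave no measurable inhibition, whereas an acidic tetrazole did. The acid in compound 3 shares a hydrogen-bond donor with the tetrazole of compound 2, so compound 3 is expected to stay measurable, with a step of a 1.8-fold higher number from compound 2 to compound 3 (0.26 log units; within the scatter) that may stay within the scatter.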

Compound 3, half-maximal inhibitory concentration: 4440 nM
Beside the measured number, compound 3's estimate is 8.9-fold (0.95 log units) below it, outside the stated range (above it).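

In this assay, 1-carboxyethyl does not stand in for 1-(1H-tetrazol-5-yl)-1-methylethyl on the amide-type nitrogen, even though both groups count 1 hydrogen-bond donor; the step is a 16-fold higher number from compound 2 to compound 3 (1.21 log units; beyond the scatter). Even so, 1-carboxyethyl keeps a measurable number where 1-(methoxycarbonyl)-1-methylethyl does not, a step of an at least 2.2-fold lower number from compound 1 to compound 3 (0.35 log units; beyond the scatter). That step is anchored on a limit and not on a number, so its true size is unknown: the limit of > 10000 nM in this assay, at which 1 of the 3 values shown sits.

From the compounds shown here alone, the change from compound 2 to compound 3 swaps the ring for a chain, drops a methyl group and adds a defined stereocentre all at once, so the share of each stays open. A 1-carboxy-1-methylethyl group on the same nitrogen would separate the tetrazole from the two chain methyl groups, and the opposite stereocentre of 1-carboxyethyl remains equally untested here.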